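The source may report more compounds than this note shows. Statements on the series, on what has been measured and on what is new or still open speak of the compounds shown alone.

Measured set:
compound 1 `Cc1ccc(NC(=O)CCc2cn(Cc3ccc4oc(-c5ccccc5)cc(=O)c4c3)nn2)cc1` gives 15600 nM in an assay on isolated protein for inhibition of Amine oxidase [flavin-containing] B (Homo sapiens), read by fluorescence and spectrophotometry; on this read-out higher numbers stand for weaker inhibition and lower numbers for stronger inhibition;
compound 2 `O=C(CCc1cn(Cc2ccc3oc(-c4ccccc4)cc(=O)c3c2)nn1)Nc1ccc(Cl)cc1` gives 15600 nM in this assay;
compound 3 `O=C(CCCCc1cn(Cc2ccc3oc(-c4ccccc4)cc(=O)c3c2)nn1)Nc1ccc(F)cc1` gives 15600 nM in this assay.

Compound 3 stands level with compound 1 and compound 2 at the digits shown: from compound 1 to compound 3 no change at the digits printed from compound 1 to compound 3 (within the scatter), and from compound 2 to compound 3 no change at the digits printed from compound 2 to compound 3 (within the scatter).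

Compound 4 `Cc1ccc(NC(=O)CCCCc2cn(Cc3ccc4oc(-c5ccccc5)cc(=O)c4c3)nn2)cc1` differs from compound 3 by methyl in place of fluoro on an aromatic carbon. Among the compounds with values here, the only measured step on the same ring is from compound 1 to compound 2, no change at the digits printed from compound 1 to compound 2 (within the scatter), a swap of two ring substituents with no effect; the steps into compound 3 were likewise flat. A step of no size beyond the scatter is therefore expected, no change at the digits printed from compound 3 to compound 4 (within the scatter), and compound 4 is estimated at 15600 nM in this assay, between 7800 nM and 31200 nM.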

Compound 4, half-maximal inhibitory concentration: 15600 nM
Estimate against measurement, compound 4: no gap at the digits printed; measured number inside the range.
By their numbers in this assay, from the lowest: compounds 1, 2, 3 and 4 (each within the scatter of the next).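

In this assay, methyl and fluoro on the aromatic carbon para to a large group are now compared on the chain of compound 3, with no change at the digits printed from compound 3 to compound 4 (within the scatter), so the flat ring swap seen on the chain of compound 1 also holds here. Changing chain and ring substituent together is equally flat, with no change at the digits printed from compound 2 to compound 4 (within the scatter) and no change at the digits printed from compound 1 to compound 4 (within the scatter). No supporting data bear on this flatness.

Open, going by these compounds, is whether an amine or a carboxylic acid at this ring position would shift the value. Also open, on these data alone, is whether a longer chain would do so.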